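Swapping chloro for methoxy on the 4-aryl group

This account rests on a few compounds, and the source may have more. Where it says the series, first, only, none or still open, it means among the compounds named here.

Measured in a functional assay on A549 cells (Homo sapiens) for antiproliferative activity, read by MTT assay, with a stated time of 48 h; on this read-out lower numbers stand for stronger inhibition and higher numbers for weaker inhibition:
Compound 1 `Fc1ccc2[nH]c(-c3cn(-c4ccccc4)nc3-c3ccccc3)nc2c1`: 1720 nM
Compound 2 `Fc1ccc(-c2nn(-c3ccccc3)cc2-c2nc3cc(F)ccc3[nH]2)cc1`: 1130 nM
Compound 3 `Fc1ccc2[nH]c(-c3cn(-c4ccccc4)nc3-c3ccc(Cl)cc3)nc2c1`: 4610 nM

Compound 3 has the highest number of the three, so it is the weakest inhibitor in this small set. The next compound, compound 4 `COc1ccc(-c2nn(-c3ccccc3)cc2-c2nc3cc(F)ccc3[nH]2)cc1`, keeps the shared core but changes one group, 4-chlorophenyl to 4-methoxyphenyl: methoxy in place of chloro on an aromatic carbon.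

For the measured compounds named here, no compound here carries methoxy yet, so the evidence is indirect. Three measured steps involve this same place. With hydrogen in place of chloro, the comparison gives a 2.7-fold higher number from compound 1 to compound 3 (0.43 log units; beyond the scatter). With fluoro in place of chloro, it gives a 4.1-fold higher number from compound 2 to compound 3 (0.61 log units; beyond the scatter). The step between hydrogen and fluoro is smaller: a 1.5-fold lower number from compound 1 to compound 2 (0.18 log units; within the scatter). So in these three compounds, chloro is the only group that stands apart, and both other groups give lower numbers. If methoxy behaves like hydrogen and fluoro, a modest drop in this assay would follow, though this is only an expectation from very few compounds. The expected change is a 2.3-fold lower number from compound 3 to compound 4 (0.36 log units; beyond the scatter). For compound 4 the estimated value is 2000 nM, with an expected range from 750 nM to 5500 nM.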

Compound 4, half-maximal inhibitory concentration: 1980 nM
Compound 4: middle estimate off by 1.0-fold (0.00 log units), on the high side, and the stated range covers the measured number.
By their numbers in this assay, from the lowest: compounds 2, 1 and 4 (each within the scatter of the next); then compound 3.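

Measured in this assay methoxy, which brings a hydrogen-bond acceptor that chloro lacks, gives a lower number than chloro at this position (a 2.3-fold lower number from compound 3 to compound 4 (0.37 log units; beyond the scatter)). Methoxy cannot be told apart from the two smaller substituents, since the steps from fluoro (a 1.8-fold higher number from compound 2 to compound 4 (0.24 log units; within the scatter)) and from hydrogen (a 1.2-fold higher number from compound 1 to compound 4 (0.06 log units; within the scatter)) both lie within the scatter, so these three groups have no order among themselves. Chloro therefore remains the only one of the four groups that stands apart, and the higher number it gives does not appear with every replacement of hydrogen at this position: methoxy has more heavy atoms than chloro, yet its number stays level with that of the unsubstituted compound 1.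

No measurement at hand explains what separates chloro from the other three groups. Going by these compounds, it remains open whether bromo, an amine, a carboxylic acid or a longer chain such as ethoxy at this same position would group with chloro or with hydrogen, fluoro and methoxy.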